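The compounds below may be only part of what the source reports. "The series", "measured", "known", "first", "only" and "open" are said of these compounds alone.

Measured compounds:
- compound 1 `COc1ccc(CNC(=O)[C@H](CSCC2CCCC2)NC(=O)OC(C)(C)C)cc1` — in a functional assay on IMR-32 cells for inhibition of Voltage-dependent N-type calcium channel subunit alpha-1B (Homo sapiens), read by calcium flux (a lower number here means a stronger inhibitor, a higher number a weaker inhibitor), compound 1 gives 630 nM
- compound 2 `COc1ccc(COC(=O)[C@H](COC(=O)C2CCCCC2)NC(=O)OC(C)(C)C)cc1` — in this assay compound 2 gives 1600 nM

Compound 1 stands as the lowest of the two numbers seen so far; its nearest neighbour is compound 2, and the gap between the two values lies beyond the scatter. Going by the values given here, the two compounds differ in several places at once, so their values show only that compound 1 is the stronger inhibitor of the pair; nothing further can be read from them.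

Compound 3 `COc1ccc(CNC(=O)[C@H](CSCC2CCCCC2)NC(=O)OC(C)(C)C)cc1` has not been measured. It differs from compound 1 in one place: cyclohexyl in place of cyclopentyl on a saturated chain carbon bound to a sulfur. Among the compounds with values here, no step between two measured compounds speaks to this change, so there is no measured precedent to lean on. The step is a small one in structure, and the expectation is that the step from compound 1 to compound 3 will be small, likely within the scatter, with no clear direction.

Compound 3 is therefore expected to show a 1.3-fold lower number from compound 1 to compound 3 (0.10 log units; within the scatter) and to land near 500 nM, with a range from 200 nM to 1500 nM.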

Compound 3, half-maximal inhibitory concentration: 610 nM
Compound 3: middle estimate off by 1.2-fold (0.09 log units), on the low side; the measured number falls inside the stated range.
By their numbers in this assay, from the lowest: compounds 3 and 1 (each within the scatter of the next); then compound 2.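

In this assay, going by these compounds alone, the first single-place change, cyclohexyl in place of cyclopentyl on a saturated chain carbon bound to a sulfur, gives a 1.0-fold lower number from compound 1 to compound 3 (0.01 log units; within the scatter) and leaves compound 1 and compound 3 indistinguishable. At this position, then, the added ring carbon brings no reading that stands out from the scatter, and the two rings can be exchanged here without any visible consequence for the number in this assay; before this pair, no measured comparison spoke to this position at all. Nothing available explains why the two rings read alike.

What the compounds shown leave open is how far this insensitivity extends, since they cover only these two saturated carbon rings and say nothing about a phenyl ring, a longer open chain, an amine or a carboxylic acid at the same place. Compound 2 differs from the others in several places at once, so the separate contributions of the sulfur-bearing chain and of the amide linkage also remain unresolved.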